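Extending the Amine Chain from a Limit Value

This account rests on a few compounds, and the source may have more. Where it says the series, first, only, none or still open, it means among the compounds named here.

In a functional assay on HeLa cells (Homo sapiens) for antiproliferative activity, read by MTT assay, with a stated time of 48 h (on this read-out lower numbers stand for stronger inhibition and higher numbers for weaker inhibition), compound 3 `CCN(CC)CCn1c(N)c(-c2nc3ccccc3n2C)c2nc(C#N)c(C#N)nc21` gives > 50000 nM, which is a limit of the assay and not a number. Compound 2 `CN(C)CCn1c(N)c(-c2nc3ccccc3n2C)c2nc(C#N)c(C#N)nc21` gives > 50000 nM, also a limit. Both stand on (the limit of > 50000 nM in this assay, at which 2 of the 3 values shown sit). Among the compounds with values here, the only measured step here is a step that the two limits leave unreadable from compound 2 to compound 3, so it supplies no size to carry forward.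

Compound 4 `CCN(CC)CCCCn1c(N)c(-c2nc3ccccc3n2C)c2nc(C#N)c(C#N)nc21` differs from compound 3 by one change: 2-(diethylamino)ethyl in place of diethylamino on a saturated chain carbon, two bonds along the chain from an aromatic nitrogen. Read one bond further out, this is 2-(diethylamino)ethyl to 4-(diethylamino)butyl.

Within the data shown here, the one reading with the longer chain comes from compound 1 `CCN(CC)CCCCn1c(N)c(-c2nc3ccccc3o2)c2nc(C#N)c(C#N)nc21`, which carries 4-(diethylamino)butyl alongside a different aromatic group on the shared core. In this assay, compound 1 gives 6420 nM. With that single value as support, a move towards stronger inhibition is expected, though its size remains uncertain and compound 4 may yet reach the limit. The expected change is an at least 2.7-fold lower number from compound 3 to compound 4 (0.44 log units; beyond the scatter). Compound 4 is estimated at 18000 nM, with an expected range of 5000 nM to 50000 nM.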

Compound 4, half-maximal inhibitory concentration: 1610 nM
Compound 4: the middle estimate sits 11-fold (1.05 log units) above what was measured, and the stated range ends above it.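

In this assay, extending the chain to 4-(diethylamino)butyl turns a compound with no readable number into a measured one, giving an at least 31-fold lower number from compound 3 to compound 4 (1.49 log units; beyond the scatter), and the comparison with the dimethylamino compound gives an at least 31-fold lower number from compound 2 to compound 4 (1.49 log units; beyond the scatter). Both steps are open-ended, because compound 2 and compound 3 each stand on a limit of the assay and not on a number: the limit of > 50000 nM in this assay, at which 2 of the 4 values shown sit. With the 4-(diethylamino)butyl chain held constant, the aromatic group also matters, as 1-methyl-1H-benzimidazol-2-yl in place of 1,3-benzoxazol-2-yl gives a 4.0-fold lower number from compound 1 to compound 4 (0.60 log units; beyond the scatter).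

The compounds shown leave open whether a 3-(diethylamino)propyl chain or a chain longer than 4-(diethylamino)butyl would read the same way, and whether a piperidine at the chain end could replace the diethylamino group. They also leave open how 1,3-benzoxazol-2-yl would read on the 2-(diethylamino)ethyl chain.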